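The source may report more compounds than this note shows. Statements on the series, on what has been measured and on what is new or still open speak of the compounds shown alone.

The measured compounds:

Compound 1, `COc1ccc2[nH]cc(C3(c4c[nH]c5ccc(OC)cc45)C(=O)Nc4ccccc43)c2c1`, gives 2200 nM
Compound 2, `COc1ccc2c(C3(c4c[nH]c5cc(OC)ccc45)C(=O)Nc4ccccc43)c[nH]c2c1`, gives 1200 nM
Compound 3, `COc1ccc2[nH]cc(C3(c4c[nH]c5ccc(OC)cc45)C(=O)Nc4ccc(F)cc43)c2c1`, gives 3600 nM

All three were tested in a functional assay on DU-145 cells (Homo sapiens) for cytotoxicity, read by MTT assay, with a stated time of 48 h; on this read-out lower numbers stand for stronger inhibition and higher numbers for weaker inhibition. Compound 1 and compound 3 share one core, and compound 3 differs from compound 1 in a single place: fluoro in place of hydrogen on an aromatic carbon. The step measured in this assay is a 1.6-fold higher number from compound 1 to compound 3 (0.21 log units; within the scatter), so the reading of compound 3 sits close to that of compound 1. Compound 2 is built from the same atoms as compound 1, joined differently; the difference between the two cores is not broken down here. In this assay compound 2 gives 1200 nM, which is close to the reading of compound 1 but clearly apart from that of compound 3.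

Compound 4, `COc1ccc2c(C3(c4c[nH]c5cc(OC)ccc45)C(=O)Nc4ccc(F)cc43)c[nH]c2c1`, has not yet been measured. It stands to compound 2 as compound 3 stands to compound 1: fluoro in place of hydrogen on an aromatic carbon. This is the same change, made at the same kind of place, on the other core, and it occurs twice among these compounds. For the measured compounds named here, the one measured instance, a 1.6-fold higher number from compound 1 to compound 3 (0.21 log units; within the scatter), is the only guide to what it does. Because that instance was a 1.6-fold higher number from compound 1 to compound 3 (0.21 log units; within the scatter), the step in this assay from compound 2 to compound 4 is expected to be of similar size, a 1.6-fold higher number from compound 2 to compound 4 (0.20 log units; within the scatter). Starting from compound 2 with its 1200 nM, compound 4 is therefore estimated at 1900 nM in this assay. The expected range for compound 4 runs from 900 nM to 4000 nM. The range is wide: a single prior example of the change is a thin basis.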

Compound 4, half-maximal inhibitory concentration: 13100 nM
Beside the measured number, compound 4's estimate is 6.9-fold (0.84 log units) below it, outside the stated range (above it).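

On the core of compound 2, fluoro in place of hydrogen on an aromatic carbon brings a large step in this assay, an 11-fold higher number from compound 2 to compound 4 (1.04 log units; beyond the scatter). Set beside the earlier case, the size of this step clearly did not carry over from one core to the other: the same change on two cores in this assay, a 1.6-fold higher number (0.21 log units; within the scatter) from compound 1 to compound 3 and an 11-fold higher number (1.04 log units; beyond the scatter) from compound 2 to compound 4, 6.7-fold (0.82 log units) apart, beyond the scatter of two such steps. In this series, then, a step read on one core can be a poor guide to the same change on the other, but with one change on two cores, these numbers do not show why the cores part ways or whether any other change would behave the same.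

The compounds shown leave open whether another group on the same aromatic carbon, such as chloro, methyl or an amine, would also give steps of different size on the two cores. They also leave open whether the gap between the cores would hold up for the same fluoro change in a different kind of cell.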